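The compounds below may be only part of what the source reports. "The series", "measured", "known", "first", "only" and "open" are said of these compounds alone.

Three compounds share one core and differ only in the groups hung on it. Compound 1 `O=C(Nc1cccc(-n2cc(-c3ccncc3)c(-c3ccc(Cl)c(O)c3)n2)c1)Nc1cccc(C(F)(F)F)c1` gives 2120 nM in a functional assay on TK-10 cells (Homo sapiens) for inhibition, read by sulforhodamine B assay, with a stated time of 48 h; on this read-out higher numbers stand for weaker inhibition of growth and lower numbers for stronger inhibition of growth. Compound 2 `O=C(Nc1cccc(-n2cc(-c3ccncc3)c(-c3ccc(Cl)c(O)c3)n2)c1)Nc1ccc(Cl)c(Cl)c1` gives 1910 nM there, and the step of a 1.1-fold lower number from compound 1 to compound 2 (0.05 log units; within the scatter) shows that swapping the aryl group on the urea nitrogen changes little. Compound 3 `COc1cc(-c2nn(-c3cccc(NC(=O)Nc4ccc(Cl)c(C(F)(F)F)c4)c3)cc2-c2ccncc2)ccc1Cl` gives 1520 nM, the lowest of the three numbers, though its gaps to compound 2 and to compound 1 both lie within the scatter, so the three cannot be ranked.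

Compound 4 `O=C(Nc1cccc(-n2cc(-c3ccncc3)c(-c3ccc(Cl)c(O)c3)n2)c1)Nc1ccc(Cl)c(C(F)(F)F)c1` is reached from compound 3 by one change: hydrogen in place of methyl on an oxygen on an aromatic ring, that is, methoxy to hydroxy, giving a 4-chloro-3-hydroxyphenyl group. Within the data shown here, no measured step tests this exact change; compounds 1 and 2 already carry the hydroxy, compound 3 the methoxy, and all three sit within the scatter of one another. The step from compound 3 to compound 4 is therefore expected to be small, a 1.2-fold higher number from compound 3 to compound 4 (0.07 log units; within the scatter), with no clear direction. Compound 4 is estimated at 1800 nM, with a range from 900 nM to 3600 nM.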

Compound 4, concentration for 50% growth inhibition: 1500 nM
For compound 4 the middle estimate is 1.2-fold (0.08 log units) above the measured one; the measured number falls inside the stated range.
By their numbers in this assay, from the lowest: compounds 4, 3, 2 and 1 (each within the scatter of the next).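

In this assay, methoxy to hydroxy on the 4-chloro-3-methoxyphenyl group now has a direct test, and the step stays within the scatter (a 1.0-fold lower number from compound 3 to compound 4 (0.01 log units; within the scatter)), so the two groups cannot be told apart on this compound pair. With the 4-chloro-3-hydroxyphenyl group held fixed, changes on the other aryl group of the urea also stay within the scatter, both for trifluoromethyl in place of chloro (a 1.3-fold lower number from compound 2 to compound 4 (0.10 log units; within the scatter)) and for chloro in place of hydrogen (a 1.4-fold lower number from compound 1 to compound 4 (0.15 log units; within the scatter)). No measurement here offers an explanation for these results.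

Still open, on these data alone, is whether an ethyl group or a longer chain on this oxygen, or an amine in place of the hydroxy, would stand apart from these values. Also open, as far as these compounds go, is whether methoxy to hydroxy reads the same with the aryl groups of compounds 1 and 2.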